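A few compounds are considered here, and "the series" means these few. Any claim that something is new, unique, unknown or untested is made for them only; others in the source may bear on it.

In a functional assay on HT-29 cells (Homo sapiens) for cytotoxicity, read by MTT assay, with a stated time of 72 h (a lower number here means a stronger inhibitor, a higher number a weaker inhibitor), compound 1 `O=C(CN1CCN(c2nnc(Cc3ccccc3)c3ccccc23)CC1)Nc1ccc(F)c(C(F)(F)F)c1` gives 4590 nM, the second highest of the three numbers at hand. Compound 2 `O=C(CN1CCN(c2nnc(Cc3ccncc3)c3ccccc23)CC1)Nc1ccc(F)c(C(F)(F)F)c1` gives 1110 nM, so the step is a 4.1-fold lower number from compound 1 to compound 2 (0.62 log units; beyond the scatter). For the measured compounds named here, compound 3 `COc1ccc(NC(=O)CN2CCN(c3nnc(Cc4ccncc4)c4ccccc34)CC2)cc1OC` gives 40100 nM, and the step of a 36-fold higher number from compound 2 to compound 3 (1.56 log units; beyond the scatter) is the only measured change on the amide-type nitrogen. Compound 4 `Cc1cccc(Cl)c1NC(=O)CN1CCN(c2nnc(Cc3ccccc3)c3ccccc23)CC1` differs from compound 1 at that same place: 2-chloro-6-methylphenyl in place of 4-fluoro-3-(trifluoromethyl)phenyl on an amide-type nitrogen. Because a 36-fold higher number from compound 2 to compound 3 (1.56 log units; beyond the scatter) was large, a change here is expected to weaken inhibition, though the entering group differs from the one tried before, so a more modest rise in this assay is expected. Compound 4 is therefore expected to give 12000 nM, between 3500 nM and 40000 nM, a step of a 2.6-fold higher number from compound 1 to compound 4 (0.42 log units; beyond the scatter).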

Compound 4, half-maximal inhibitory concentration: 53600 nM
The estimate for compound 4 lay 4.5-fold (0.65 log units) below the measured number, outside the stated range (above it).
By their numbers in this assay, from the lowest: compound 2; then compound 1; then compounds 3 and 4 (each within the scatter of the next).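

The step of a 12-fold higher number from compound 1 to compound 4 (1.07 log units; beyond the scatter) in this assay shows that replacing 4-fluoro-3-(trifluoromethyl)phenyl on the amide-type nitrogen can also give a large rise when phenyl, not pyridin-4-yl, occupies the other site. Both replacements shown at this place, 3,4-dimethoxyphenyl and 2-chloro-6-methylphenyl, raise the number, and no compound shown goes against this. Going by these compounds, it remains open whether 2-chloro-6-methylphenyl would act alike with pyridin-4-yl, and how an amine or a carboxylic acid on this aromatic ring would read. No measurement given here accounts for the rise.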